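Compound 4 in the biaryl imidazoline series: thiophene for hydroxyphenyl

This account rests on a few compounds, and the source may have more. Where it says the series, first, only, none or still open, it means among the compounds named here.

For the measured compounds named here, compound 2 `CC(Oc1ccccc1-c1ccccc1O)C1=NCCN1` gives 1620 nM in an assay on CHO cells for displacement of a labelled ligand from Alpha-2C adrenergic receptor (Homo sapiens) (a higher number here means a weaker inhibitor, a lower number a stronger inhibitor), the highest of the three numbers so far; compound 1 `CC(Oc1ccccc1-c1ccccc1[N+](=O)[O-])C1=NCCN1` gives 1230 nM, and compound 3 `CC(Nc1ccccc1-c1ccccc1)C1=NCCN1` gives 708 nM. Going by the values given here, the only measured step is a 1.3-fold higher number from compound 1 to compound 2 (0.12 log units; within the scatter). Among the compounds with values here, compound 4 `CC(Oc1ccccc1-c1cccs1)C1=NCCN1` differs from compound 2 by thiophen-2-yl in place of 2-hydroxyphenyl on an aromatic carbon, a change no measured step directly covers. Compound 3 carries an unsubstituted phenyl and a different linker, so it shows only that removal of the hydroxy ring substituent can go with a lower number. A modest step downward or none beyond the scatter is expected, as a 1.6-fold lower number from compound 2 to compound 4 (0.21 log units; within the scatter). For compound 4 the estimate in this assay is 1000 nM, with a range of 400 nM to 2500 nM.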

Compound 4, inhibition constant: 72.4 nM
For compound 4 the middle estimate is 14-fold (1.14 log units) above the measured one; measured number outside the range, below it.
By their numbers in this assay, from the lowest: compound 4; then compounds 3, 1 and 2 (each within the scatter of the next, the first and the last beyond it).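

At this aromatic carbon, ortho to a group of 8 heavy atoms, the choice of ring matters in this assay: thiophen-2-yl in place of 2-hydroxyphenyl gives a 22-fold lower number from compound 2 to compound 4 (1.35 log units; beyond the scatter), whereas the earlier step, a 1.3-fold higher number from compound 1 to compound 2 (0.12 log units; within the scatter), showed no clear change at this carbon. Nothing measured here bears on the reason for the new step. Still open, going by these compounds, is whether the step belongs to the thiophene ring itself or to the loss of the hydroxy-bearing ring. A plain phenyl or a furan-2-yl at this carbon, on the same core, would separate the two.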